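The source may report more compounds than this note shows. Statements on the series, on what has been measured and on what is new or still open speak of the compounds shown alone.

Working notes on the series. In a functional assay with Rattus norvegicus as the target (on this read-out lower numbers stand for an effect already at smaller amounts and higher numbers for an effect only at larger amounts of compound), compound 1 `CC(C)(C)c1ccc(C/N=C(\S)NC(c2ccccc2)c2ccc(NS(C)(=O)=O)cc2)cc1` gives > 100000 nM, which is a limit of the assay and not a number. Compound 2 `C[C@@H](/N=C(\S)NCc1ccc(C(C)(C)C)cc1)c1ccc([N+](=O)[O-])cc1` gives > 100000 nM, again a limit and not a number. Among the compounds with values here, the whole record so far is the limit of > 100000 nM in this assay, at which 2 of the 2 values shown sit, so compound 2 stands level with the only other measured compound and has no numeric value of its own.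

The next change leads to compound 3 `C[C@@H](/N=C(\S)NCc1ccc(C(C)(C)C)cc1)c1ccc(N)cc1`, with amino in place of nitro on an aromatic carbon, para to a large group: amino in place of nitro on an aromatic carbon.

Within the data shown here, no measured step gives a size for this kind of change. The expectation therefore rests on compound 2 alone, whose > 100000 nM is a limit. The expected change, an at least 2.5-fold lower number from compound 2 to compound 3 (0.39 log units; beyond the scatter), is an estimated shift towards lower numbers in this assay, and it may be small; a further reading at the same limit is about as likely as a number. The estimated value for compound 3 is 40000 nM, with an expected range from 4000 nM to 100000 nM.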

Compound 3, half-maximal effective concentration: > 100000 nM
Compound 3 was reported as a limit; the forecaster's own chance of this, stated with the estimate: 55%; middle value at least 2.5-fold (0.39 log units) away from the limit.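

In this assay compound 3 gives > 100000 nM, a limit and not a number. No size can be read for amino in place of nitro between compound 2 and compound 3, since the record holds only limits: the limit of > 100000 nM in this assay, at which 3 of the 3 values shown sit.

The compounds shown leave open whether any member of this series gives a numeric value in this assay, and how far any single change would move it.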